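The source may report more compounds than this note shows. Statements on the series, on what has been measured and on what is new or still open speak of the compounds shown alone.

Measured compounds:
compound 1 `CNC(=O)CC1CCc2cc(OC)c(OC)cc21` gives 15.6%
compound 2 `COc1cc2c(cc1OC)C(CC(=O)NC(C)(C)C)CC2` gives 31.3%

In a functional assay on the whole organism (strain Wistar) for inhibition, with Rattus norvegicus as the target, read by paw edema, with stated times of 60 min and 1 h, at a dose of 100 mg/kg by the oral route (a higher number here means more inhibition at the dose given (going by the name of the read-out), a lower number less inhibition), compound 2 stands highest of the two numbers; its nearest neighbour is compound 1, which lies lower by a number 15.7 percentage points higher from compound 1 to compound 2 (beyond the scatter). That single step, tert-butyl in place of methyl on an amide-type nitrogen, is the only one measured so far and is the only one that bears on what follows. Compound 3 `COc1cc2c(cc1OC)C(CC(=O)N1CCCC1)CC2` has not yet been measured. It differs from compound 2 in one place: pyrrolidin-1-yl in place of (tert-butyl)amino on a carbonyl carbon. Among the compounds with values here, the group that leaves and the group that enters are matched in size, but no measured pair shows what closing the amide nitrogen into a ring does here, so the step in this assay is expected to stay within the scatter, with a number 3.3 percentage points lower from compound 2 to compound 3 (within the scatter) as the estimated change. Compound 3 is expected to give about 28%, in a range from 10% to 45%.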

Compound 3, a percentage reported as inhibition, in the whole organism at one dose (the size of the read-out at that dose, not a potency): 4.69%
The estimate for compound 3 lay 23.3 percentage points above the measured number, and the stated range ends above it.
By their numbers in this assay, from the lowest: compound 3; then compound 1; then compound 2.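

In this assay the group on the carbonyl carbon matters even at equal size: (tert-butyl)amino and pyrrolidin-1-yl hold the same count of heavy atoms, yet the change gives a number 26.6 percentage points lower from compound 2 to compound 3 (beyond the scatter) in the paw swelling read-out. Pyrrolidin-1-yl also falls short of the smaller methylamino, with a number 10.9 percentage points lower from compound 1 to compound 3 (beyond the scatter) for that change, so size alone does not order these three compounds; the two that keep the amide hydrogen both stand above the ring compound. Nothing at hand explains the drop.

Going by these compounds, it stays open whether dimethylamino, which has no amide hydrogen and no ring, would sit as low as compound 3, or whether the loss comes with the ring itself. A larger ring such as piperidin-1-yl, or a carboxylic acid in place of the amide, could also help separate these possibilities.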